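Dropping the Acyl Group on the Ring Nitrogen

This account rests on a few compounds, and the source may have more. Where it says the series, first, only, none or still open, it means among the compounds named here.

Of the compounds shown here, three built on one shared core have been tested in a functional assay on MDA-MB-231 cells (Homo sapiens) for cytotoxicity, read by sulforhodamine B assay, with a stated time of 72 h; a lower number here means a stronger inhibitor of growth, a higher number a weaker inhibitor of growth. Compound 3 `O=C(Nc1cc(C(F)(F)F)cc(C(F)(F)F)c1)C1CCc2ccccc2N1C(=O)c1ccc(Cl)cc1` gives 2000 nM, the lowest of the two numbers measured. Compound 2 `COc1ccc(NC(=O)C2CCc3ccccc3N2)cc1` gives 51400 nM, a higher number that lies well beyond the scatter. Compound 1 `CCC(=O)N1c2ccccc2CCC1C(=O)Nc1ccccc1C(F)(F)F` reaches only the limit of this assay, > 80000 nM, so no number is known for it (the limit of > 80000 nM in this assay, at which 1 of the 3 values shown sits). Compound 4 `O=C(Nc1cc(C(F)(F)F)cc(C(F)(F)F)c1)C1CCc2ccccc2N1` has not yet been measured; it differs from compound 3 by hydrogen in place of (4-chlorophenyl)carbonyl on a nitrogen on an aromatic ring in a ring. Going by the values given here, no measured pair in this set differs in only that one place, so the size of the step cannot be read directly from the numbers. Compound 2, which also carries hydrogen on that nitrogen, gives 51400 nM in this assay. On that basis the change from compound 3 to compound 4 is expected to weaken growth inhibition, by a 10-fold higher number from compound 3 to compound 4 (1.00 log units; beyond the scatter), though with a different anilide the comparison is loose. Compound 4 is estimated at 20000 nM, within a range from 5000 nM to 80000 nM.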

Compound 4, concentration for 50% growth inhibition: 8270 nM
Estimate against measurement, compound 4: 2.4-fold (0.38 log units) above, within the range that was stated.
By their numbers in this assay, from the lowest: compound 3; then compound 4; then compound 2. At a limit, above all of these: compound 1.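

Going by these compounds alone, replacing the (4-chlorophenyl)carbonyl with hydrogen on the ring nitrogen gives, in this assay, the first direct reading of this position (a 4.1-fold higher number from compound 3 to compound 4 (0.62 log units; beyond the scatter)). The group therefore adds to growth inhibition here but is not required for it, since compound 4, with only hydrogen on that nitrogen, still gives a measured number (8270 nM) rather than a limit. Nothing measured in this set explains why removing the group has this effect.

From the compounds shown here alone, it remains open whether a benzyl group or a methanesulfonyl group on that nitrogen would match the (4-chlorophenyl)carbonyl, and whether a plain benzoyl group would do so without the chlorine. Compound 1 and compound 2 also differ from compound 3 and compound 4 in the group on the amide nitrogen, so no further single-place steps can be read.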